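Swapping Chloro for Trifluoromethyl on the Anilide Ring

The source may report more compounds than this note shows. Statements on the series, on what has been measured and on what is new or still open speak of the compounds shown alone.

Measured so far:
compound 1, `COC(=O)c1ccc(NC(=O)C2(C(=O)Nc3ccc(Nc4ncc5cc(C(=O)N(C)C)n(C6CCCC6)c5n4)cc3)CC2)cc1`, growth inhibition 77.1%
compound 2, `CN(C)C(=O)c1cc2cnc(Nc3ccc(NC(=O)C4(C(=O)Nc5cccc(Cl)c5)CC4)cc3)nc2n1C1CCCC1`, growth inhibition 8.3%

Both numbers come from a functional assay on A549 cells (Homo sapiens) for inhibition, read by CCK-8 assay, with a stated time of 72 h, tested at 1 uM; a higher number here means more inhibition of growth at the concentration tested, a lower number less inhibition of growth. Among the compounds with values here, compound 2 stands lowest of the two; the only neighbour is compound 1, and the drop a number 68.8 percentage points lower from compound 1 to compound 2 (beyond the scatter) is the single step known so far. That step changes the whole aryl group on the amide-type nitrogen, so it says nothing directly about a smaller exchange on that ring.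

Compound 3, `CN(C)C(=O)c1cc2cnc(Nc3ccc(NC(=O)C4(C(=O)Nc5cccc(C(F)(F)F)c5)CC4)cc3)nc2n1C1CCCC1`, keeps the shared core of compound 2 and differs in one place: trifluoromethyl in place of chloro on an aromatic carbon. Within the data shown here, no measured pair shows this exchange, so there is no step to lean on, only the knowledge that compound 2 itself sits at the low end and that both groups are small and uncharged. A change of modest size is expected, with the direction open; the estimated step of a number 6.7 percentage points higher from compound 2 to compound 3 (within the scatter) is expected to stay within, or barely beyond, the usual scatter. Compound 3 is therefore estimated at 15%, within a range from 0% to 45%.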

Compound 3, percent growth inhibition at one concentration: 15.7%
Compound 3: middle estimate off by 0.7 percentage points, on the low side; the measured number falls inside the stated range.
By their numbers in this assay, from the lowest: compounds 2 and 3 (each within the scatter of the next); then compound 1.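

In this assay, putting trifluoromethyl in place of chloro on this aromatic carbon, meta to a large group, gives a number 7.4 percentage points higher from compound 2 to compound 3 (within the scatter), so this exchange makes no readable difference even though trifluoromethyl holds more heavy atoms than chloro. The 3-(trifluoromethyl)phenyl group also gives a number 61.4 percentage points lower from compound 1 to compound 3 (beyond the scatter), so the large gap first seen with the 3-chlorophenyl group appears with a second anilide ring and is not tied to chloro alone. No supporting evidence is available to explain either result.

The compounds shown cannot separate the identity of the ring substituent from its place, as none carries methoxycarbonyl on the ring position held by chloro and trifluoromethyl, or either of those two groups on the ring position held by methoxycarbonyl in compound 1. They also leave open how a carboxylic acid or an amine would read in this assay on this ring, and whether the high value of compound 1 needs the methyl ester specifically.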